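Moving the methyl group on the benzamide ring

The source may hold more compounds than are shown below. What is called first, only, known or untested is meant among the compounds shown, and "the series" means these compounds.

Compound 1 `Cc1ccc(S(=O)(=O)NCc2ccc(CNC(=O)c3cccc(F)c3)cc2)cc1`: 1 nM
Compound 2 `Cc1ccc(S(=O)(=O)NCc2ccc(CNC(=O)c3ccccc3C)cc2)cc1`: 100 nM

Of the compounds shown here, two have been measured in an assay on MDA-MB-231 cells for binding affinity to C-X-C chemokine receptor type 4 (Homo sapiens), read by immunofluorescence and microscopy, with stated times of 10 min and 30 min; on this read-out lower numbers stand for an effect already at smaller amounts and higher numbers for an effect only at larger amounts of compound. Compound 1 gives 1 nM and compound 2 gives 100 nM. On the numbers shown, compound 2 stands highest of the two, with compound 1 as its nearest neighbour. For the measured compounds named here, the one measured step, a 100-fold higher number from compound 1 to compound 2 (2.00 log units; beyond the scatter), is large and beyond the scatter.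

Compound 3 `Cc1ccc(C(=O)NCc2ccc(CNS(=O)(=O)c3ccc(C)cc3)cc2)cc1` differs from compound 2 in one place: 4-methylphenyl in place of 2-methylphenyl on a carbonyl carbon. The same atoms are joined differently. Going by the values given here, no measured step covers this particular change; the only step at hand, a 100-fold higher number from compound 1 to compound 2 (2.00 log units; beyond the scatter), changes both the substituent and its ring position at once, so it bears on compound 3 only loosely. Compound 3 is therefore expected to give 30 nM (range 3 nM to 300 nM) in this assay, an estimated step of a 3.3-fold lower number from compound 2 to compound 3 (0.52 log units; beyond the scatter), with wide uncertainty.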

Compound 3, effective concentration (reported as EC, without a stated level of effect): 1000 nM
Compound 3: the middle estimate sits 33-fold (1.52 log units) below what was measured; measured number above the stated range.
By their numbers in this assay, from the lowest: compound 1; then compound 2; then compound 3.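

In this assay, the change from 2-methylphenyl to 4-methylphenyl on the carbonyl carbon gives a 10-fold higher number from compound 2 to compound 3 (1.00 log units; beyond the scatter), so the place of the methyl group matters even with the substituent itself kept the same, which the earlier step could not separate. Replacing 3-fluorophenyl with 4-methylphenyl gives a 1000-fold higher number from compound 1 to compound 3 (3.00 log units; beyond the scatter), a larger step than the one between the two methylphenyl groups. No evidence is at hand that accounts for these steps.

The compounds shown leave open whether the fluorine atom or its ring position sets compound 1 apart, since each methyl comparison with compound 1 changes both at once. From the compounds shown here alone, how a chlorine atom, a methoxy group or an amine on the same phenyl ring would read in this assay also remains open.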